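The source may hold more compounds than are shown below. What is called first, only, known or untested is meant among the compounds shown, and "the series" means these compounds.

Compound 1 `Nc1scc(CN2CCN(c3cccc(Cl)c3Cl)CC2)c1C(=O)c1ccc(Cl)cc1` is built around a shared core carrying a 2,3-dichlorophenyl group on an amine nitrogen in a ring. In a functional assay on CHO cells with adenosine receptor A1 (Homo sapiens) as the target, read by cAMP accumulation and immunoassay, with a stated time of 6 min, tested at 10 uM (on this read-out higher numbers stand for a weaker effect at the one concentration tested and lower numbers for a stronger effect), compound 1 gives -77%, the lowest of the three numbers measured, and on this read-out the strongest effect. Compound 2 `COc1ccc(N2CCN(Cc3csc(N)c3C(=O)c3ccc(Cl)cc3)CC2)cc1` carries a 4-methoxyphenyl in that same place and gives -52% in this assay, a change of a number 25 percentage points higher from compound 1 to compound 2 (beyond the scatter). Compound 3 `Nc1scc(CN2CCN(c3ccc(Cl)c(C(F)(F)F)c3)CC2)c1C(=O)c1ccc(Cl)cc1` carries a 4-chloro-3-(trifluoromethyl)phenyl there and gives -60%, a change of a number 17 percentage points higher from compound 1 to compound 3 (beyond the scatter). Between compound 2 and compound 3 the difference is a number 8 percentage points lower from compound 2 to compound 3 (within the scatter).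

Compound 4 `Nc1scc(CN2CCN(c3ccncc3)CC2)c1C(=O)c1ccc(Cl)cc1` differs from compound 1 by pyridin-4-yl in place of 2,3-dichlorophenyl on an amine nitrogen in a ring. Both earlier swaps of this group away from 2,3-dichlorophenyl raised the number by a modest amount beyond the scatter, so a similar weakening is expected here. The expected step is a number 32 percentage points higher from compound 1 to compound 4 (beyond the scatter). For compound 4 in this assay the estimate is -45%, in a range from -70% to -15%.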

Compound 4, a percentage reported as activity, at one concentration (the size of the read-out at that concentration, not a potency): -15%
The estimate for compound 4 lay 30 percentage points below the measured number, within the range that was stated.
By their numbers in this assay, from the lowest: compound 1; then compounds 3 and 2 (each within the scatter of the next); then compound 4.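

In this assay, pyridin-4-yl gives much bigger steps than any seen so far at this place on the ring nitrogen: a number 62 percentage points higher from compound 1 to compound 4 (beyond the scatter), a number 45 percentage points higher from compound 3 to compound 4 (beyond the scatter) and a number 37 percentage points higher from compound 2 to compound 4 (beyond the scatter), which leaves compound 4 with the weakest effect of the four. Substituted phenyl groups at this place differ from each other by modest steps at most, whereas this change, the only one that puts a nitrogen into the aromatic ring, costs far more of the effect. Nothing available explains this loss.

The step from compound 1 to compound 4 swaps the ring and removes both chlorines at once, so the two changes cannot be told apart. An unsubstituted phenyl group would help separate them, and pyridin-3-yl would test whether the location of the ring nitrogen matters.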